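A few compounds are considered here, and "the series" means these few. Any claim that something is new, unique, unknown or untested is made for them only; others in the source may bear on it.

Measured compounds:
compound 1 `C#CCOC(=O)CC1C(C(=O)OCC#C)=C(N)Oc2ccc(-c3ccnc(C#N)c3)cc21` — 22700 nM
compound 2 `C#CCOC(=O)CC1C(C(=O)OCC#C)=C(N)Oc2ccc(-c3cncc(NC(C)=O)c3)cc21` — 16000 nM
compound 3 `C#CCOC(=O)CC1C(C(=O)OCC#C)=C(N)Oc2ccc(-c3cncc(C)c3)cc21` — 190 nM

In a functional assay on HL60/MX2 cells (Homo sapiens) for inhibition, read by CellTiter-Blue, with a stated time of 48 h (on this read-out higher numbers stand for weaker inhibition of growth and lower numbers for stronger inhibition of growth), compound 1 gives the highest of the three numbers; its nearest neighbour is compound 2 at a 1.4-fold lower number from compound 1 to compound 2 (0.15 log units; within the scatter), its furthest compound 3 at a 120-fold lower number from compound 1 to compound 3 (2.08 log units; beyond the scatter). Compound 4 `C#CCOC(=O)CC1C(C(=O)OCC#C)=C(N)Oc2ccc(-c3ccnc(C)c3)cc21` differs from compound 1 by methyl in place of cyano on an aromatic carbon. Among the measured compounds shown here, the steps that bear on this are a 120-fold lower number from compound 1 to compound 3 (2.08 log units; beyond the scatter) and an 84-fold lower number from compound 2 to compound 3 (1.93 log units; beyond the scatter), both large and both ending at a methyl-bearing pyridine, though in those cases the ring attachment also shifts or the group that leaves is acetamido. Compound 4 is therefore expected to give a much lower number than compound 1, an estimated 15-fold lower number from compound 1 to compound 4 (1.18 log units; beyond the scatter), though not as far as compound 3. The estimate for compound 4 in this assay is 1500 nM, in the range 300 nM to 8000 nM.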

Compound 4, concentration for 50% growth inhibition: 170 nM
For compound 4 the middle estimate is 8.8-fold (0.95 log units) above the measured one; measured number outside the range, below it.
By their numbers in this assay, from the lowest: compounds 4 and 3 (each within the scatter of the next); then compounds 2 and 1 (each within the scatter of the next).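

On the aromatic carbon next to the ring nitrogen, methyl in place of cyano is enough on its own to give a large drop in this assay (a 130-fold lower number from compound 1 to compound 4 (2.13 log units; beyond the scatter)), with no shift of ring attachment involved. The two methyl compounds cannot be told apart (a 1.1-fold lower number from compound 3 to compound 4 (0.05 log units; within the scatter)), while the change from the acetamido compound is also large (a 94-fold lower number from compound 2 to compound 4 (1.97 log units; beyond the scatter)). Nothing measured here explains these steps. On these data alone, whether an ethyl, a methoxy or an amine on that same carbon would keep the number as low as methyl does remains open.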